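The source may report more compounds than this note shows. Statements on the series, on what has been measured and on what is new or still open speak of the compounds shown alone.

Compound 1 `CC[C@H](C)[C@H](NS(=O)(=O)c1cc(Br)c(Br)s1)C(=O)N[C@@H](CNC(=O)OCc1ccccc1)C(=O)NO`: 52 nM
Compound 2 `CC[C@@H](C)[C@@H](NC(=O)OCc1ccccc1)C(=O)NCC(NCc1ccccc1)C(=O)NO`: 94 nM
Compound 3 `CNC(=O)[C@H](CCC(N)=O)NC(=O)[C@H](CC(=O)O)CC(=O)NO`: 68000 nM

In an assay on isolated protein for inhibition of bone morphogenetic protein 1 (Homo sapiens) (a lower number here means a stronger inhibitor, a higher number a weaker inhibitor), compound 1 gives 52 nM, the lowest of the three numbers. Compound 2 gives 94 nM, and the two values lie within the scatter of one another, so nothing separates them. Compound 3 gives 68000 nM, a gap far beyond the scatter. Within the data shown here, no pair of measured compounds differs in a single place, so compound 1 serves only as the starting point for compound 4 `CC[C@H](C)[C@H](NS(=O)(=O)c1cc(C)c(Cl)cc1C)C(=O)N[C@@H](CNC(=O)OCc1ccccc1)C(=O)NO`, which has not yet been measured. The change from compound 1 to compound 4 is 4-chloro-2,5-dimethylphenyl in place of 4,5-dibromothiophen-2-yl on a sulfonyl sulfur. Among the measured compounds shown here, no measured pair shows what such an exchange does in this assay, so the direction of the step is open. Because compound 1 gives 52 nM, compound 4 is expected to stay near it, and the expected step of a 1.5-fold higher number from compound 1 to compound 4 (0.19 log units; within the scatter) is a small weakening that may not exceed the scatter. The value for compound 4 is estimated at 80 nM, within a range from 25 nM to 300 nM.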

Compound 4, half-maximal inhibitory concentration: 67 nM
Beside the measured number, compound 4's estimate is 1.2-fold (0.08 log units) above it, and the stated range covers the measured number.
By their numbers in this assay, from the lowest: compounds 1, 4 and 2 (each within the scatter of the next); then compound 3.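

In this assay, the step for 4-chloro-2,5-dimethylphenyl in place of 4,5-dibromothiophen-2-yl on a sulfonyl sulfur is a 1.3-fold higher number from compound 1 to compound 4 (0.11 log units; within the scatter), so the two compounds cannot be told apart. This position therefore accepts a six-membered aromatic ring of carbon only as well as a five-membered aromatic ring with 1 hetero atom, and the ring sulfur and the bromines are not needed for a number of this size on the core of compound 1. Nothing measured here accounts for why the two groups read alike.

On these data alone, whether a cyclohexyl group, a pyridine ring or a plain butyl chain on the sulfonyl sulfur would hold the number in this assay remains open. Compound 4 also changes the ring and its substituents together, so the part played by the chlorine or the methyl groups alone cannot be separated.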